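This account rests on a few compounds, and the source may have more. Where it says the series, first, only, none or still open, it means among the compounds named here.

Measured in an ADME assay on microsomes from liver (Homo sapiens) for metabolic stability, using NADPH, with a stated time of 10 min; on this read-out higher numbers stand for a more stable compound and lower numbers for a less stable compound:
Compound 1 `CCCCc1nc(=O)c(S(=O)(=O)c2ccc(-c3ccc(F)cc3)cc2)c(O)n1-c1c(OC)cccc1OC`: 100%
Compound 2 `CCCCc1[nH]c(=O)c(S(=O)(=O)c2ccc(-c3ccc(F)nc3)cc2)c(O)c1-c1c(OC)cccc1OC`: "not determined" (no result reported)

Among the measured compounds shown here, compound 1 is the only compound with a number to stand on. In this assay compound 1 gives 100%, while compound 2 has "not determined" (no result reported), so the two cannot be compared. Compound 3 `CCCCc1nc(=O)c(S(=O)(=O)c2ccc(C3CC3)cc2)c(O)n1-c1c(OC)cccc1OC` keeps the core of compound 1 but carries cyclopropyl in place of 4-fluorophenyl on an aromatic carbon. For the measured compounds named here, no measured pair shows what such a change does, so any forecast in this assay rests on little. Compound 1, at 100%, leaves no visible room for a rise. A small fall or no change beyond the scatter therefore seems most likely. The expected change is a number 12 percentage points lower from compound 1 to compound 3 (beyond the scatter). For compound 3 the estimated value is 88%, with an expected range from 65% to 100%.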

Compound 3, percent of the compound remaining: 95%
For compound 3 the middle estimate is 7 percentage points below the measured one; low and high end bracket the measured number.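

In this assay, the series now has its first readable step: cyclopropyl in place of 4-fluorophenyl on an aromatic carbon, para to a large group, gives a number 5 percentage points lower from compound 1 to compound 3 (within the scatter). For this pair, then, the six-membered aromatic ring of carbon only can give way to a three-membered non-aromatic ring, with 3 heavy atoms instead of 7, without a difference that can be told apart on this read-out. No measurement at hand offers an explanation for this result.

Among the compounds shown here, the single pair cannot show whether the same holds for other kinds of group at this position, such as an amine, a carboxylic acid or a longer alkyl chain. It also leaves open whether cyclopropyl would behave in the same way on a different core.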